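This account rests on a few compounds, and the source may have more. Where it says the series, first, only, none or still open, it means among the compounds named here.

In a functional assay on HepG2 cells (Homo sapiens) for cytotoxicity, read by MTT assay, with a stated time of 24 h (on this read-out higher numbers stand for weaker inhibition and lower numbers for stronger inhibition), compound 1 (`Cc1ccc(S(=O)(=O)N2C/C(=C\c3cccnc3)C(=O)/C(=C/c3ccccc3F)C2)cc1`) gives 4200 nM, compound 2 (`O=C1/C(=C/c2ccncc2)CN(S(=O)(=O)c2ccc([N+](=O)[O-])cc2)C/C1=C\c1ccccc1F`) gives 11300 nM and compound 3 (`Cc1ccc(S(=O)(=O)N2C/C(=C\c3cccnc3)C(=O)/C(=C/c3ccccc3C(F)(F)F)C2)cc1`) gives 2930 nM. Compound 3 thus lies within the scatter of compound 1, while compound 2 stands beyond the scatter on the higher side of compound 3. The next compound, compound 4 (`CC(=O)Nc1ccc(S(=O)(=O)N2C/C(=C\c3cccnc3)C(=O)/C(=C/c3ccccc3C(F)(F)F)C2)cc1`), keeps everything in compound 3 except for one change: acetamido in place of methyl on an aromatic carbon, para to a large group (acetamido in place of methyl on an aromatic carbon). For the measured compounds named here, the only measured step between compounds differing in one place is a 1.4-fold lower number from compound 1 to compound 3 (0.16 log units; within the scatter). It swaps trifluoromethyl for fluoro elsewhere in the molecule, so it says nothing directly about this change. Going by the values given here, no measured step isolates the methyl group, which leaves no basis for predicting a shift in either direction, so no change beyond the scatter in this assay is expected. The estimated step is a 1.2-fold higher number from compound 3 to compound 4 (0.08 log units; within the scatter). The expected value for compound 4 is 3500 nM, with an estimated range of 1400 nM to 9000 nM.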

Compound 4, half-maximal inhibitory concentration: 4330 nM
Compound 4: middle estimate off by 1.2-fold (0.09 log units), on the low side, and the stated range covers the measured number.
By their numbers in this assay, from the lowest: compounds 3, 1 and 4 (each within the scatter of the next); then compound 2.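

In this assay the swap of methyl for acetamido on an aromatic carbon, para to a large group, gives a 1.5-fold higher number from compound 3 to compound 4 (0.17 log units; within the scatter) and is the only step shown that isolates this position. A group with more heavy atoms, carrying a hydrogen-bond donor and a hydrogen-bond acceptor that methyl lacks, can therefore stand here without a shift beyond the scatter on this read-out. Nothing measured alongside these compounds bears on why the number holds.

Going by these compounds, whether an amine, a carboxylic acid or a longer acyl chain at this position would move the number beyond the scatter remains open. So does whether acetamido would give the same result with fluoro in place of trifluoromethyl, as in the core of compound 1.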